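The source may report more compounds than this note shows. Statements on the series, on what has been measured and on what is new or still open speak of the compounds shown alone.

Measured in a functional assay on MCF7 cells (Homo sapiens) for inhibition; on this read-out higher numbers stand for weaker inhibition of growth and lower numbers for stronger inhibition of growth:
Compound 1 `COC(=O)c1ccsc1NC(=O)[C@@H]1CCCN1`: > 250 ug/mL (a limit of the assay, not a number)
Compound 2 `O=C(OC1CCCCC1)c1ccsc1NC(=O)[C@@H]1CCCN1`: 162 ug/mL
Compound 3 `O=C1CC[C@@H](COC(=O)c2ccsc2NC(=O)[C@@H]2CCCN2)N1`: 148 ug/mL

Compound 3 stands level with its nearest measured neighbour, the step being a 1.1-fold lower number from compound 2 to compound 3 (0.04 log units; within the scatter). Compound 1 rests on (the limit of > 250 ug/mL in this assay, at which 1 of the 3 values shown sits).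

Compound 4 `C=CCOC(=O)c1ccsc1NC(=O)[C@@H]1CCCN1` has not yet been measured. It carries vinyl in place of 5-oxopyrrolidin-2-yl on a saturated chain carbon bound to an oxygen next to a carbonyl group.

The other steps that bear on this change alter the group at the same oxygen: an at least 1.5-fold lower number from compound 1 to compound 2 (0.18 log units; that floor lies within the scatter), and an at least 1.6-fold lower number from compound 1 to compound 3 (0.22 log units; that floor lies within the scatter). None of the three goes beyond the scatter, so no step beyond the scatter is expected in this assay, and the estimate is a 1.2-fold higher number from compound 3 to compound 4 (0.09 log units; within the scatter). For compound 4 the expected value is 180 ug/mL, with an estimated range of 100 ug/mL to 320 ug/mL.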

Compound 4, concentration for 50% growth inhibition: 96.6 ug/mL
Compound 4: middle estimate off by 1.9-fold (0.27 log units), on the high side; the measured number lies below the stated range.
By their numbers in this assay, from the lowest: compounds 4, 3 and 2 (each within the scatter of the next). At a limit, above all of these: compound 1.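

In this assay, allyl in place of (5-oxopyrrolidin-2-yl)methyl gives a 1.5-fold lower number from compound 3 to compound 4 (0.19 log units; within the scatter), and allyl in place of cyclohexyl gives a 1.7-fold lower number from compound 2 to compound 4 (0.22 log units; within the scatter), so these three groups on the oxygen stand level. Allyl in place of methyl gives the only step here beyond the scatter, an at least 2.5-fold lower number from compound 1 to compound 4 (0.41 log units; beyond the scatter). That step is only a floor, as compound 1 rests on a limit of the assay: the limit of > 250 ug/mL in this assay, at which 1 of the 4 values shown sits.

Going by these compounds, whether a longer chain or a terminal amine at this oxygen would stay level with allyl in this assay remains open.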